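The source may hold more compounds than are shown below. What is called first, only, known or untested is meant among the compounds shown, and "the series" means these compounds.

Of the compounds shown here, three have been measured in an assay on isolated protein for inhibition of aldehyde dehydrogenase 1A1 (Homo sapiens), read by spectrophotometry, tested at 10 uM; a higher number here means more inhibition at the concentration tested (going by the name of the read-out), a lower number less inhibition. Compound 1, with the structure `Cc1cccc(Cn2c(CN3CCN(C(=O)c4ccc(C(C)C)cc4)CC3)nc3ccccc32)c1`, gives 67.6% and stands highest of the three numbers. Compound 2, `O=C(C1CC1)N1CCN(Cc2nc3ccccc3n2Cc2ccc(Cl)cc2)CC1`, gives 56.6%, a number beyond the scatter below compound 1. Compound 3, `COc1cccc(Cn2c(CN3CCN(C(=O)C4CC4)CC3)nc3ccccc32)c1`, gives 44.4%, the furthest from compound 1. Among the compounds with values here, the one single-point step measured so far, a number 12.2 percentage points lower from compound 2 to compound 3 (beyond the scatter), concerns the group on the saturated chain carbon bound to the aromatic nitrogen, not the carbonyl end.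

Compound 4, `Cc1cccc(Cn2c(CN3CCN(C(=O)C4CCC4)CC3)nc3ccccc32)c1`, differs from compound 1 at that carbonyl end: cyclobutyl in place of 4-isopropylphenyl on a carbonyl carbon. Within the data shown here, no measured step shows how the group on the carbonyl carbon affects inhibition, since compound 2 and compound 3 differ from compound 1 in two places at once. Still, the two compounds carrying a small carbocycle on the carbonyl, compound 2 and compound 3, both sit below compound 1, so a modest drop is expected: a number 15.6 percentage points lower from compound 1 to compound 4 (beyond the scatter). Compound 4 is therefore estimated at 52%, in a range from 35% to 68%.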

Compound 4, a percentage reported as inhibition, at one concentration (the size of the read-out at that concentration, not a potency): 69.1%
The estimate for compound 4 lay 17.1 percentage points below the measured number; the whole stated range lies below it.
By their numbers in this assay, from the lowest: compound 3; then compound 2; then compounds 1 and 4 (each within the scatter of the next).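

In this assay, within the data shown here, the change of group on the carbonyl carbon gives a number 1.5 percentage points higher from compound 1 to compound 4 (within the scatter), the first reading of this end of the molecule with everything else held constant. Cyclobutyl has 4 heavy atoms and a four-membered non-aromatic ring, whereas 4-isopropylphenyl has 9 heavy atoms and a six-membered aromatic ring, so in this pair neither the aromatic ring nor the larger group is needed to keep the reading at this level at the concentration tested. No supporting evidence is available to explain why the two groups read alike.

On these data alone, it remains open whether a carbonyl carbon bearing a dimethylamino group, a carboxylic acid or a longer chain such as n-butyl would read alike too. Whether the same holds with a different group on the saturated chain carbon bound to the aromatic nitrogen is also unknown.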